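Exchanging the aromatic group of compound 2

The source may report more compounds than this note shows. Statements on the series, on what has been measured and on what is new or still open speak of the compounds shown alone.

In an ADME assay on Caco-2 cells (Homo sapiens) for permeability, in the apical to basolateral direction, with a stated time of 90 min, tested at 10 uM (on this read-out lower numbers stand for lower permeability and higher numbers for higher permeability), compound 1 (`O=C(NC[C@@H]1[C@H]2CN(C(=O)OCc3cc(Cl)cc(Cl)c3)C[C@@H]12)c1ccc2[nH]c(=O)oc2c1`) gives 137 10^-6 cm/s and compound 2 (`CC(OC(=O)N1C[C@@H]2[C@@H](CNC(=O)c3ccc4[nH]c(=O)oc4c3)[C@@H]2C1)c1cc(Cl)cc(Cl)c1`) gives 118 10^-6 cm/s, so compound 2 stands level with compound 1 within the scatter. Among the measured compounds shown here, the only measured step, a 1.2-fold lower number from compound 1 to compound 2 (0.06 log units; within the scatter), is a methyl in place of hydrogen. Compound 3 (`Cc1cc(COC(=O)N2C[C@@H]3[C@@H](CNC(=O)c4ccc5[nH]c(=O)oc5c4)[C@@H]3C2)no1`) instead carries a group of 7 heavy atoms (5 carbon, 1 nitrogen, 1 oxygen; one five-membered aromatic ring with 2 hetero atoms) in place of a group of 10 heavy atoms (8 carbon, 2 chlorine; one six-membered aromatic ring of carbon only), on an oxygen next to a carbonyl group. For the measured compounds named here, no measured step covers this exchange, so the small methyl step offers little guidance, and the expectation remains uncertain. A moderate fall in this assay is expected, an estimated 1.7-fold lower number from compound 2 to compound 3 (0.23 log units; within the scatter). For compound 3 the estimated value is 70 10^-6 cm/s, with an expected range of 30 10^-6 cm/s to 140 10^-6 cm/s.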

Compound 3, apparent permeability in the Caco-2 assay: 2 10^-6 cm/s
Estimate against measurement, compound 3: 35-fold (1.54 log units) above; the measured number lies below the stated range.
By their numbers in the Caco-2 assay, from the lowest: compound 3; then compounds 2 and 1 (each within the scatter of the next).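

On an oxygen next to a carbonyl group, the choice of aromatic group moves the numbers far more than the earlier methyl did: in the Caco-2 assay there is a 59-fold lower number from compound 2 to compound 3 (1.77 log units; beyond the scatter), and likewise a 69-fold lower number from compound 1 to compound 3 (1.84 log units; beyond the scatter). In a physicochemical assay for solubility, with a stated time of 24 h, at pH 4.5 (on this read-out higher numbers stand for higher solubility and lower numbers for lower solubility), the same exchange runs the opposite way, with an at least 93-fold higher number from compound 2 to compound 3 (1.96 log units; beyond the scatter). In the physicochemical assay compound 2 gives < 1 ug/mL, which is a limit of the assay. In the physicochemical assay compound 3 gives > 93 ug/mL, which is also a limit of the assay. Both solubility values are limits of the assay, not exact numbers: the measured solubility of compound 2, < 1 ug/mL, and of compound 3, > 93 ug/mL, an at least 93-fold higher number (1.96 log units; beyond the scatter)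

The compounds shown leave open where a group such as pyridyl or 4-chlorophenyl would fall in the Caco-2 assay and in the physicochemical assay. They also leave open how far the true solubility gap exceeds these limits.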